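The source may hold more compounds than are shown below. What is called first, only, known or untested is meant among the compounds shown, and "the series" means these compounds.

Measured so far:
Compound 1, `Cc1csc2cc([C@H](C)Nc3ncnc(N)c3C#N)c(-c3ccccc3)c(=O)n12`: 0%
Compound 2, `Cc1csc2cc([C@H](C)Nc3ncnc(N)c3C#N)c(Cc3cccc(CN4CCC4)c3)c(=O)n12`: 0.5%

Both compounds were read in an ADME assay on the whole organism (lung, Rattus norvegicus) for metabolic stability, read by LC-MS, with a stated time of 4 h; a higher number here means that more of the compound is left, a lower number that less of the compound is left. In this assay compound 1 gives 0%. In this assay compound 2 gives 0.5%. Compound 2 carries the larger of the two numbers only nominally: the gap to compound 1, its nearest neighbour, lies within the scatter, so the two readings say the same thing, that almost none of either compound is left after the stated time.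

Compound 3, `Cc1csc2cc([C@H](C)Nc3ncnc(N)c3C#N)c(Cc3cccc(CN(C)C)c3)c(=O)n12`, differs from compound 2 in one place: dimethylamino in place of azetidin-1-yl on a saturated chain carbon bound to an aromatic carbon. Among the compounds with values here, no pair of measured compounds shows what a change of this kind does to the read-out, so there is no measured step to lean on. Within the data shown here, compound 2 gives 0.5%, and nothing among the measured compounds has moved far from that reading. The step of a number 1.5 percentage points higher from compound 2 to compound 3 (within the scatter) is therefore expected to be none beyond the scatter. Compound 3 is estimated at 2%, within a range from 0% to 10%.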

Compound 3, percent of the compound remaining: 0.2%
Compound 3: middle estimate off by 1.8 percentage points, on the high side, and the stated range covers the measured number.
By their numbers in this assay, from the lowest: compounds 1, 3 and 2 (each within the scatter of the next).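

In this assay, putting dimethylamino in place of azetidin-1-yl on a saturated chain carbon bound to an aromatic carbon gives a number 0.3 percentage points lower from compound 2 to compound 3 (within the scatter), so opening the four-membered ring does not lift the reading away from almost nothing left. A wider swap at the aromatic carbon, 3-((dimethylamino)methyl)benzyl in place of phenyl, gives a number 0.2 percentage points higher from compound 1 to compound 3 (within the scatter), and so this change also produces no reading that stands apart from the others. Nothing available here explains why so little of these compounds is left after the stated time.

With every reading this close to nothing, the compounds shown cannot reveal whether either swap has any real effect, since a difference would only become visible in a compound that survives better. As far as these compounds go, it remains open whether a morpholine or a carboxylic acid in place of the amine on this chain would leave more of the compound, or whether a change to the shared core, such as replacing the nitrile with an amide, would be needed instead.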